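Growing the ether branch on a sulfonyl ketone core

The source may hold more compounds than are shown below. What is called first, only, known or untested is meant among the compounds shown, and "the series" means these compounds.

Measured compounds:
compound 1, `COCC1=CS(=O)(=O)c2ccccc2C1=O`: 99.9%
compound 2, `CCOCC1=CS(=O)(=O)c2ccccc2C1=O`: 92.4%

In a functional assay on the whole organism for inhibition, with Mus musculus as the target, at a dose of 10 mg/kg (on this read-out higher numbers stand for more inhibition at the one dose given (going by the name of the read-out) and lower numbers for less inhibition), compound 1 gives 99.9%, the highest of the two numbers in hand, though compound 2 sits within the usual scatter of it. Within the data shown here, the one measured step, a number 7.5 percentage points lower from compound 1 to compound 2 (within the scatter), shows that a small enlargement on the chain beside the ether oxygen left the read-out essentially unchanged.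

Compound 3, `CC(C)OCC1=CS(=O)(=O)c2ccccc2C1=O`, has not been measured in this assay. It differs from compound 1 as follows: isopropyl in place of methyl on an oxygen on a saturated carbon. Read one bond further out, the methoxymethyl group becomes an isopropoxymethyl group. Among the measured compounds shown here, this is a larger enlargement at the same place than the one from compound 1 to compound 2, and that step was within the scatter; no measured step tells how a branched group behaves here.

For compound 3 the expected result is therefore a modest lowering, a number 11.9 percentage points lower from compound 1 to compound 3 (beyond the scatter), estimated at 88% with a range from 65% to 100%.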

Compound 3, a percentage reported as inhibition, in the whole organism at one dose (the size of the read-out at that dose, not a potency): 99.2%
Beside the measured number, compound 3's estimate is 11.2 percentage points below it; the measured number falls inside the stated range.
By their numbers in this assay, from the lowest: compounds 2, 3 and 1 (each within the scatter of the next).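

Isopropyl brings the first branched group to the oxygen on this saturated carbon, and in this assay even this change, with three carbons entering where one left, gives only a small step (a number 0.7 percentage points lower from compound 1 to compound 3 (within the scatter)). Read from the other side, adding a methyl on the saturated chain carbon bound to the oxygen also stays small (a number 6.8 percentage points higher from compound 2 to compound 3 (within the scatter)), so the unbranched and branched ethers here cannot be told apart on this read-out at this single dose, and no measurement in hand gives a reason for this.

From the compounds shown here alone, what remains open is how far this position can be enlarged or changed, since a longer chain such as butyl, a phenyl ring or an amine at the end of the chain has no number here. A single dose also leaves open whether these ethers would separate at a lower dose.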